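The source may report more compounds than this note shows. Statements on the series, on what has been measured and on what is new or still open speak of the compounds shown alone.

Measured so far:
- compound 1, `Cc1ccc(NC(=O)Nc2cccc(CNc3ncnc4ccccc34)c2)cc1`: 24900 nM in a functional assay on A549 cells (Homo sapiens) for antiproliferative activity, read by MTT assay; on this read-out lower numbers stand for stronger inhibition and higher numbers for weaker inhibition
- compound 2, `COc1ccccc1NC(=O)Nc1cccc(CNc2ncnc3cc(OC)c(OC)cc23)c1`: 15200 nM in this assay

Compound 2 carries the smaller of these two numbers, but its gap from compound 1 lies within the usual scatter, so the two stand level. Compound 3, `COc1cc2ncnc(NCc3cccc(NC(=O)Nc4ccc([N+](=O)[O-])cc4)c3)c2cc1OC`, is not yet measured. It differs from compound 2 by one change: 4-nitrophenyl in place of 2-methoxyphenyl on an amide-type nitrogen. For the measured compounds named here, no step between measured compounds speaks to this change, so nothing beyond the scatter is expected from it in either direction. For compound 3 the estimate in this assay is 13000 nM, within a range of 4500 nM to 40000 nM, meaning an expected step of a 1.2-fold lower number from compound 2 to compound 3 (0.07 log units; within the scatter).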

Compound 3, half-maximal inhibitory concentration: > 50000 nM
Compound 3: only a limit was reported (the forecaster's own chance of this, stated with the estimate: 10%); at least 3.8-fold (0.58 log units) between middle value and limit.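

For compound 3, the value of > 50000 nM in this assay is a limit, not a number. Even so, 4-nitrophenyl in place of 2-methoxyphenyl on an amide-type nitrogen gives an at least 3.2-fold higher number from compound 2 to compound 3 (0.51 log units; beyond the scatter), the first change shown to move this read-out beyond the scatter, so the group at this position matters here. The full size of that step cannot be read: the limit of > 50000 nM in this assay, at which 1 of the 3 values shown sits.

The compounds shown leave open whether the nitro group or the change of ring position drives this step. As far as these compounds go, whether a 4-aminophenyl or 4-methoxyphenyl group on the same nitrogen would read like compound 2 also stays open.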